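A few compounds are considered here, and "the series" means these few. Any claim that something is new, unique, unknown or untested is made for them only; others in the source may bear on it.

Measured so far:
compound 1 `COc1cc(-c2nn(-c3cccc(NC(=O)Nc4cc(C(F)(F)F)cc(C(F)(F)F)c4)c3)cc2-c2ccncc2)ccc1Cl` gives 694 nM;
compound 2 `COc1cc(-c2nn(-c3cccc(NC(=O)Nc4ccc(Cl)c(Cl)c4)c3)cc2-c2ccncc2)ccc1Cl` gives 741 nM;
compound 3 `O=C(Nc1cccc(-n2cc(-c3ccncc3)c(-c3ccc(Cl)c(O)c3)n2)c1)Nc1ccc(Cl)c(Cl)c1` gives 570 nM.

These values come from a functional assay on SK-MEL-5 cells (Homo sapiens) for inhibition, read by sulforhodamine B assay, with a stated time of 48 h; on this read-out lower numbers stand for stronger inhibition of growth and higher numbers for weaker inhibition of growth. Compound 2 holds the largest of the three numbers, yet its gaps to compound 1 and compound 3 both stay within the scatter, so no ordering can be read from them. Among the measured compounds shown here, the only measured step, a 1.3-fold lower number from compound 2 to compound 3 (0.11 log units; within the scatter), concerns an oxygen group and does not touch the part changed here. Compound 4 `COc1cc(-c2nn(-c3cccc(NC(=O)c4ccc(Cl)c(C(F)(F)F)c4)c3)cc2-c2ccncc2)ccc1Cl` differs from compound 2 by 4-chloro-3-(trifluoromethyl)phenyl in place of (3,4-dichlorophenyl)amino on a carbonyl carbon. For the measured compounds named here, no measured step bears on this change, so the expectation rests on compound 2 alone and is held loose: compound 4 is expected to land near 900 nM, within 300 nM to 3000 nM, a step of a 1.2-fold higher number from compound 2 to compound 4 (0.08 log units; within the scatter) from compound 2.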

Compound 4, concentration for 50% growth inhibition: 1380 nM
For compound 4 the middle estimate is 1.5-fold (0.19 log units) below the measured one; the range from low to high includes it.
By their numbers in this assay, from the lowest: compounds 3, 1, 2 and 4 (each within the scatter of the next, the first and the last beyond it).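

In this assay, the step of a 1.9-fold higher number from compound 2 to compound 4 (0.27 log units; within the scatter) shows that 4-chloro-3-(trifluoromethyl)phenyl can take the place of (3,4-dichlorophenyl)amino on this carbonyl carbon without a change beyond the scatter. The group that leaves has 1 hydrogen-bond donor and the group that enters has 0, so this pair gives no sign that the donor is needed for growth inhibition. Nothing measured here explains the result. Still open, from the compounds shown here alone, is how growth inhibition responds to a morpholine ring or a carboxylic acid on this carbonyl carbon.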